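A few compounds are considered here, and "the series" means these few. Any claim that something is new, unique, unknown or untested is made for them only; others in the source may bear on it.

Measured so far in an assay on CHO cells for antagonist activity at transient receptor potential cation channel subfamily V member 1 (Homo sapiens), read by FLIPR; a higher number here means a weaker inhibitor, a lower number a stronger inhibitor:
compound 1, `CCC1CCN(c2cc(C(F)(F)F)ccc2CNC(=O)C(C)c2ccc(NS(C)(=O)=O)c(F)c2)CC1`: 0.7 nM
compound 2, `CCCCCCSc1cc(C(F)(F)F)ccc1CNC(=O)C(C)c1ccc(NS(C)(=O)=O)c(F)c1`: 1.8 nM

Of the two numbers in this assay, compound 2 holds the higher one; its nearest neighbour is compound 1, and the step of a 2.6-fold higher number from compound 1 to compound 2 (0.41 log units; beyond the scatter) lies beyond the scatter. Going by the values given here, that single step, which swaps 4-ethylpiperidin-1-yl for hexylsulfanyl on the same aromatic carbon, is the only comparison available and is modest in size.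

Compound 3, `CC(C(=O)NCc1ccc(C(F)(F)F)cc1F)c1ccc(NS(C)(=O)=O)c(F)c1`, follows from compound 2 by the change (fluoro in place of hexylsulfanyl on an aromatic carbon). Among the compounds with values here, no measured pair covers a change of this kind: the one recorded step trades one seven-or-more-atom group for another at that position, whereas here the whole hexylsulfanyl is removed and a single fluorine takes its place. The step from compound 1 to compound 2 therefore gives only a weak anchor; it shows that the group at this carbon can shift the number, but not by how much a truncation of this extent would do so.

For compound 3 the number in this assay is expected to rise, with the step of an 8.3-fold higher number from compound 2 to compound 3 (0.92 log units; beyond the scatter) judged to be clearly beyond the scatter and larger than the recorded one. The estimate for compound 3 is 15 nM, with a range from 3 nM to 80 nM.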

Compound 3, inhibition constant: 68.7 nM
For compound 3 the middle estimate is 4.6-fold (0.66 log units) below the measured one; the range from low to high includes it.
By their numbers in this assay, from the lowest: compound 1; then compound 2; then compound 3.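

Working notes on the aromatic carbon that carries the variable group, ortho to a large group and meta to a trifluoromethyl group. In this assay, replacing hexylsulfanyl with fluoro gives a 38-fold higher number from compound 2 to compound 3 (1.58 log units; beyond the scatter) and is much larger than the modest step between the two large groups, which is a 2.6-fold higher number from compound 1 to compound 2 (0.41 log units; beyond the scatter) at the same carbon; replacing 4-ethylpiperidin-1-yl with fluoro gives a 98-fold higher number from compound 1 to compound 3 (1.99 log units; beyond the scatter) as the widest step in the set. Across these three compounds, the number stays low with either large group and climbs steeply only when a single fluorine takes the place, so the position is more sensitive to losing the large group than to exchanging one large group for another. No measurement on hand accounts for this rise.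

The compounds shown leave open how the number changes between the fluoro and hexylsulfanyl extremes, since an intermediate group such as a butylsulfanyl chain, a methoxy group or a small amine such as dimethylamino could fall near either end. They also leave open whether a ring matters here, which a direct comparison of piperidin-1-yl, morpholin-4-yl and an open-chain amine at this carbon could test.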